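This account rests on a few compounds, and the source may have more. Where it says the series, first, only, none or still open, it means among the compounds named here.

Compound 1, with the structure `COc1ccc(-c2nc3cc(F)ccc3s2)cc1Cl`, gives 760 nM in a functional assay on MCF7 cells (Homo sapiens) for antiproliferative activity; a lower number here means a stronger inhibitor of growth, a higher number a weaker inhibitor of growth. Compound 2, with the structure `COc1ccc(-c2nc3cc(F)ccc3s2)cc1Br`, gives 850 nM in this assay. The two differ in one place, (bromo in place of chloro on an aromatic carbon), and the step of a 1.1-fold higher number from compound 1 to compound 2 (0.05 log units; within the scatter) shows that this swap left the growth-inhibiting concentration essentially where it was.

Compound 3, with the structure `COc1ccc(-c2nc3cc(Cl)ccc3s2)cc1OC`, gives 27900 nM in this assay, a much higher number than either of the first two. The difference between the core of compound 3 and the core of compound 1 is not broken down here.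

Compound 4, with the structure `COc1ccc(-c2nc3cc(Br)ccc3s2)cc1OC`, has not yet been measured. It differs from compound 3 in one place, (bromo in place of chloro on an aromatic carbon). Among the measured compounds shown here, this is the same kind of change as the one from compound 1 to compound 2, though not the same: in the first pair the carbon carrying the halogen sits ortho to a methoxy group and meta to a large group, whereas in compound 3 and compound 4 it belongs to a six-membered aromatic ring that is part of a fused system of two rings, meta to a fused ring and para to a fused ring.

Because the earlier swap gave a 1.1-fold higher number from compound 1 to compound 2 (0.05 log units; within the scatter), the step of a 1.1-fold higher number from compound 3 to compound 4 (0.03 log units; within the scatter) expected from compound 3 to compound 4 is small. The value estimated for compound 4 in this assay is 30000 nM, with a likely range from 10000 nM to 90000 nM.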

Compound 4, concentration for 50% growth inhibition: 13600 nM
Compound 4: the middle estimate sits 2.2-fold (0.34 log units) above what was measured; the range from low to high includes it.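

In this assay, putting bromo in place of chloro on an aromatic carbon of the fused ring system gave a 2.1-fold lower number from compound 3 to compound 4 (0.31 log units; beyond the scatter), a modest gain in growth inhibition. Set beside the same swap on the other core, this step does not differ from the earlier one by more than repeated measurements could explain: the same change on two cores in this assay, a 1.1-fold higher number (0.05 log units; within the scatter) from compound 1 to compound 2 and a 2.1-fold lower number (0.31 log units; beyond the scatter) from compound 3 to compound 4, 2.3-fold (0.36 log units) apart, within the scatter of two such steps This shows that, across these two pairs, the swap has a small effect on either core and that the data give no sign of the core changing its size, but it does not show that the two cores respond identically, as only two steps are available, one within the scatter and one modestly beyond it, and the halogen sits in a different place in each pair.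

The compounds shown leave open whether the same small step would appear on a third core, or with the halogen at yet another place on these two. They also leave open how a different group on the same aromatic carbon, such as iodo, an amine or a carboxylic acid, would compare with chloro and bromo.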